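Lengthening a Selenium-Bearing Chain on a Shared Core

The compounds below may be only part of what the source reports. "The series", "measured", "known", "first", "only" and "open" are said of these compounds alone.

Of the compounds shown here, three sharing one core have been measured in a functional assay on HeLa cells (Homo sapiens) for antiproliferative activity, read by MTT assay, with a stated time of 48 h; on this read-out higher numbers stand for weaker inhibition and lower numbers for stronger inhibition. Compound 1 `COc1ccc(N(C)c2ccnc(Cl)n2)cc1OCCCCCBr` gives 7090 nM, compound 2 `COc1ccc(N(C)c2ccnc(Cl)n2)cc1OCC[Se]C#N` gives 436 nM, and compound 3 `COc1ccc(N(C)c2ccnc(Cl)n2)cc1OCCC[Se]C#N` gives 4710 nM. Compound 3 therefore sits level with compound 1, since a 1.5-fold lower number from compound 1 to compound 3 (0.18 log units; within the scatter) lies within the scatter. It sits well above compound 2, the most potent of the three, and lower numbers mean stronger inhibition here.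

Compound 4 `COc1ccc(N(C)c2ccnc(Cl)n2)cc1OCCCCC[Se]C#N` has not yet been measured. It differs from compound 3 by a group of 5 heavy atoms (3 carbon, 1 nitrogen, 1 selenium; no ring) in place of a group of 3 heavy atoms (1 carbon, 1 nitrogen, 1 selenium; no ring), on a saturated chain carbon, three bonds along the chain from an oxygen on an aromatic ring. Among the measured compounds shown here, the closest guide is an 11-fold higher number from compound 2 to compound 3 (1.03 log units; beyond the scatter), the only measured step that lengthens a chain with the same end group, and it is large. The other large step, a 16-fold lower number from compound 1 to compound 2 (1.21 log units; beyond the scatter), changes the chain and the end group together, so it says less about this change. One step does not make a trend, and nothing shows that activity keeps falling as the chain grows. Compound 1 at 7090 nM also shows no number far beyond compound 3 in this small set.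

In this assay, no change beyond the scatter is expected, and the estimated step is a 1.2-fold lower number from compound 3 to compound 4 (0.07 log units; within the scatter). The expected value for compound 4 is 4000 nM, with an estimated range from 800 nM to 15000 nM.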

Compound 4, half-maximal inhibitory concentration: > 10000 nM
Compound 4 was reported as a limit (the forecaster's own chance of this, stated with the estimate: 5%); middle value at least 2.5-fold (0.39 log units) away from the limit.
By their numbers in this assay, from the lowest: compound 2; then compounds 3 and 1 (each within the scatter of the next). At a limit, above all of these: compound 4.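

Compound 4 is reported only as a limit, not as a number: the limit of > 10000 nM in this assay, at which 1 of the 4 values shown sits.

Read as floors, the new steps are an at least 2.1-fold higher number from compound 3 to compound 4 (0.32 log units; beyond the scatter) and an at least 22-fold higher number from compound 2 to compound 4 (1.36 log units; beyond the scatter), so with the same selenium and nitrile end group, each longer chain among compounds 2, 3 and 4 goes with a higher number, and the single earlier step now has a second one in the same direction. The change of one bromine atom for the selenium and nitrile group, on a saturated chain carbon, five bonds along the chain from an oxygen on an aromatic ring, gives an at least 1.4-fold higher number from compound 1 to compound 4 (0.14 log units; that floor lies within the scatter), so on this longer chain the selenium group shows no gain in this assay over bromine.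

Going by these compounds, how far compound 4 really lies beyond its limit stays unknown, and so does the true size of these steps. On these data alone, it also remains open whether the activity of compound 2, at 436 nM, depends on the selenium and nitrile group itself, which a bromine atom, an amine or a carboxylic acid on that same shorter chain would help to settle.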